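This account rests on a few compounds, and the source may have more. Where it says the series, first, only, none or still open, it means among the compounds named here.

Working notes on the series.

Compound 1 `CC(C)(N)C(=O)N[C@H](COCc1cccc(Cl)c1Cl)c1nnnn1CCOC(=O)NCCCCO` and compound 2 `CC(C)(N)C(=O)N[C@H](COCc1ccccc1C(F)(F)F)c1nnnn1CCOC(=O)NCCCCO` share one core and differ only in the aryl group on the saturated chain carbon bound to an oxygen on a saturated carbon. In a functional assay on cells for inhibition of growth hormone secretagogue receptor type 1 (Homo sapiens), read by FLIPR and calcium flux (a higher number here means that more compound is needed for the effect, a lower number that less compound is needed), compound 1 gives 0.61 nM and compound 2 gives 0.72 nM; the step of a 1.2-fold higher number from compound 1 to compound 2 (0.07 log units; within the scatter) lies within the scatter. Among the compounds with values here, compound 3 `CC(C)(N)C(=O)N[C@H](COCc1ccc(OC(F)(F)F)cc1)c1nnnn1CCOC(=O)NCCCCO` carries a 4-(trifluoromethoxy)phenyl at the same place and gives 33.2 nM in this assay, the highest of the three numbers so far. The steps of a 54-fold higher number from compound 1 to compound 3 (1.74 log units; beyond the scatter) and a 46-fold higher number from compound 2 to compound 3 (1.66 log units; beyond the scatter) are both large and beyond the scatter.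

Compound 4 `CC(C)(N)C(=O)N[C@H](COCc1ccccc1-c1cccnc1)c1nnnn1CCOC(=O)NCCCCO` has not been measured. The change from compound 3 is 2-(pyridin-3-yl)phenyl in place of 4-(trifluoromethoxy)phenyl on a saturated chain carbon bound to an oxygen on a saturated carbon. Both measured steps that bear on it, from compound 1 and from compound 2 to compound 3, show that a 2-substituted or 2,3-disubstituted phenyl at this place sits at a far lower number than the 4-substituted phenyl of compound 3. Compound 4 returns to a 2-substituted phenyl, though with a group unlike either of those measured, so a large step back down in this assay is expected, a 17-fold lower number from compound 3 to compound 4 (1.22 log units; beyond the scatter), without assuming the full return to compound 1 or compound 2. For compound 4 the expected value in this assay is 2 nM, with a range from 0.5 nM to 8 nM.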

Compound 4, half-maximal effective concentration: 1.18 nM
Estimate against measurement, compound 4: 1.7-fold (0.23 log units) above, within the range that was stated.
By their numbers in this assay, from the lowest: compounds 1, 2 and 4 (each within the scatter of the next); then compound 3.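

In this assay this position on a saturated chain carbon bound to an oxygen on a saturated carbon takes a 2-(pyridin-3-yl)phenyl, which brings a second aromatic ring, with a large step of a 28-fold lower number from compound 3 to compound 4 (1.45 log units; beyond the scatter). The earlier compounds shown here showed only small groups or halogens on the phenyl, whereas the steps of a 1.6-fold higher number from compound 2 to compound 4 (0.21 log units; within the scatter) and a 1.9-fold higher number from compound 1 to compound 4 (0.29 log units; within the scatter) show that a whole pyridin-3-yl ring in place of trifluoromethyl, or a 2-(pyridin-3-yl)phenyl in place of 2,3-dichlorophenyl, cannot be told apart within the scatter, so the three groups of compound 1, compound 2 and compound 4 stand together, with compound 3 alone apart from them. Nothing measured here explains why these groups stand together or why compound 3 stands apart.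

Compound 3 differs from the other three in both the place of its substituent on the phenyl and the group itself, so the two remain unseparated: a trifluoromethoxy group in the place held by pyridin-3-yl in compound 4 would speak to this. Also open, on these data alone, is how far the added ring of compound 4 can be changed, for instance by an aminomethyl group or a carboxylic acid on that ring.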